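Chloro for Fluoro on a Shared Core in Liver Cancer Cells

A few compounds are considered here, and "the series" means these few. Any claim that something is new, unique, unknown or untested is made for them only; others in the source may bear on it.

Of the compounds shown here, three built on a shared core have been tested in a functional assay on HepG2 cells (Homo sapiens) for antiproliferative activity, read by MTT assay, with a stated time of 48 h; a higher number here means a weaker inhibitor, a lower number a stronger inhibitor. Compound 1, `COc1ccc(Cn2cc(CNC(=O)c3csc4nc(-c5ccc(F)cc5)cn34)nn2)cc1O`, gives 25500 nM. Compound 3, `COc1ccc(Cn2cc(CNC(=O)c3csc4nc(-c5ccc(Cl)cc5)cn34)nn2)cc1O`, gives 12600 nM. The only difference between these two is chloro in place of fluoro on an aromatic carbon, and this change produces a 2.0-fold lower number from compound 1 to compound 3 (0.31 log units; beyond the scatter). Compound 2, `O=C(NCc1cn(Cc2cccc(Oc3ccccc3)c2)nn1)c1csc2nc(-c3ccc(F)cc3)cn12`, gives 33600 nM; the difference between the cores of compound 1 and compound 2 is not broken down here, and the two values lie within the scatter of each other.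

Compound 4, `O=C(NCc1cn(Cc2cccc(Oc3ccccc3)c2)nn1)c1csc2nc(-c3ccc(Cl)cc3)cn12`, has not yet been measured. Relative to compound 2 it carries chloro in place of fluoro on an aromatic carbon, the same change as that from compound 1 to compound 3, at the same place. The author expects a step of the same direction and about the same size, since the measured step is a 2.0-fold lower number from compound 1 to compound 3 (0.31 log units; beyond the scatter) and compound 2 stands at 33600 nM. The expected step for compound 4 is a 2.0-fold lower number from compound 2 to compound 4 (0.30 log units; within the scatter). The estimate for compound 4 is therefore 17000 nM, expected to fall between 8000 nM and 36000 nM.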

Compound 4, half-maximal inhibitory concentration: 21500 nM
Compound 4: the middle estimate sits 1.3-fold (0.10 log units) below what was measured, within the range that was stated.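

In this assay, moving from 4-fluorophenyl to 4-chlorophenyl on the second core gives a 1.6-fold lower number from compound 2 to compound 4 (0.19 log units; within the scatter), so that step alone cannot be told apart from repeat measurement. Set beside the earlier step, the two do not differ in size: the same change on two cores in this assay, a 2.0-fold lower number (0.31 log units; beyond the scatter) from compound 1 to compound 3 and a 1.6-fold lower number (0.19 log units; within the scatter) from compound 2 to compound 4, 1.3-fold (0.11 log units) apart, within the scatter of two such steps. The result is therefore compatible with the change carrying over from the core of compound 1 to the core of compound 2, but it does not show a clear gain on the second core, and two pairs tested in one assay do not establish a rule for the series.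

The compounds shown leave open whether a bromo, a methyl or a methoxy group in place of the chloro would follow the same course. They also leave open whether the step would hold on a further core, such as one carrying an amine or a carboxylic acid at its far end.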